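This account rests on a few compounds, and the source may have more. Where it says the series, first, only, none or still open, it means among the compounds named here.

Of the compounds shown here, three built on one shared core have so far been measured in a functional assay on L1210 cells (Mus musculus) for cytotoxicity; on this read-out lower numbers stand for stronger inhibition and higher numbers for weaker inhibition. Compound 1 `COc1ccc(NC(=O)/C=C/C(=O)N2C/C(=C\c3ccc([N+](=O)[O-])cc3)C(=O)/C(=C/c3ccc([N+](=O)[O-])cc3)C2)cc1` gives 2900 nM; compound 2 `O=C(/C=C/C(=O)N1C/C(=C\c2ccc([N+](=O)[O-])cc2)C(=O)/C(=C/c2ccc([N+](=O)[O-])cc2)C1)Nc1ccc(Cl)c(Cl)c1` gives 1700 nM; compound 3 `Cc1ccc(NC(=O)/C=C/C(=O)N2C/C(=C\c3ccc([N+](=O)[O-])cc3)C(=O)/C(=C/c3ccc([N+](=O)[O-])cc3)C2)cc1C` gives 4900 nM. Compound 3 thus carries the highest of the three numbers, though one of its two distances, a 1.7-fold higher number from compound 1 to compound 3 (0.23 log units; within the scatter), lies within the scatter, while the other, a 2.9-fold higher number from compound 2 to compound 3 (0.46 log units; beyond the scatter), is a modest step beyond it. The remaining step, a 1.7-fold lower number from compound 1 to compound 2 (0.23 log units; within the scatter), is again within the scatter.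

Compound 4 `O=C(/C=C/C(=O)N1C/C(=C\c2ccc([N+](=O)[O-])cc2)C(=O)/C(=C/c2ccc([N+](=O)[O-])cc2)C1)Nc1ccccc1` differs from compound 3 in one place: phenyl in place of 3,4-dimethylphenyl on an amide-type nitrogen. Going by the values given here, no measured pair removes substituents from this aryl group outright; the measured steps only exchange one pair of substituents for another, and the largest of them, between compound 2 and compound 3, is modest. On that basis the change from compound 3 to compound 4 is expected to move this assay little, if at all, beyond the scatter, with a slight lean toward a lower number, as a 1.4-fold lower number from compound 3 to compound 4 (0.15 log units; within the scatter). Compound 4 is therefore estimated at 3500 nM in this assay, within a range from 1500 nM to 8000 nM.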

Compound 4, half-maximal inhibitory concentration: 1800 nM
Estimate against measurement, compound 4: 1.9-fold (0.29 log units) above; measured number inside the range.
By their numbers in this assay, from the lowest: compounds 2, 4, 1 and 3 (each within the scatter of the next, the first and the last beyond it).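

Going by these compounds alone, with the unsubstituted phenyl, the aryl group on the amide-type nitrogen stands for the first time without any substituent, and in this assay the change from 3,4-dimethylphenyl to phenyl gives a 2.7-fold lower number from compound 3 to compound 4 (0.43 log units; beyond the scatter), a modest step as large as the one that earlier separated the dimethyl from the dichloro compound. The other two exchanges to phenyl stay small, with a 1.1-fold higher number from compound 2 to compound 4 (0.02 log units; within the scatter) for the loss of both chlorines and a 1.6-fold lower number from compound 1 to compound 4 (0.21 log units; within the scatter) for the loss of methoxy, so that compound 3 alone is separated from compound 4 among the three comparisons. At this position, then, no substituent on the ring is needed to keep the number at the level of compound 1 and compound 2, although nothing available here accounts for the 3,4-dimethylphenyl group standing apart.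

On these data alone, it remains open whether a single methyl or a single chlorine on the ring behaves like the pairs or like bare phenyl. As far as these compounds go, it is equally open what a carboxylic acid or an amine on that ring, or a cyclohexyl group in place of the ring, would do in this assay.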